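The compounds below may be only part of what the source reports. "The series", "measured", "known", "first", "only" and "open" are said of these compounds alone.

Working notes on the series

Two compounds of this series have a number in a functional assay on MCF7 cells (Homo sapiens) for cytotoxicity, read by sulforhodamine B assay (on this read-out lower numbers stand for stronger inhibition and higher numbers for weaker inhibition), so far. Compound 1, `C=C1[C@@H](C/C=C2/C(=O)OC[C@H]2OC(C)=O)[C@]2(C)CC[C@@H](OC(C)=O)[C@@](C)(CO[Si](C)(C)C(C)(C)C)[C@H]2C[C@@H]1O`, gives 6960 nM in this assay. Compound 2, `C=C1[C@@H](OC(C)=O)C[C@@H]2[C@](C)(COC=O)[C@H](OC(C)=O)CC[C@@]2(C)[C@@H]1C[C@@H](Nc1ccccc1C(=O)O)C1=CCOC1=O`, gives 30800 nM in this assay, the higher of the two numbers; the gap between compound 2 and compound 1 lies beyond the usual scatter, so compound 2 is the weaker of the two on what has been measured.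

The next step goes from compound 2 to compound 3, `C=C1[C@@H](OC(C)=O)C[C@@H]2[C@](C)(COC=O)[C@H](OC(C)=O)CC[C@@]2(C)[C@@H]1C[C@@H](Nc1ccc(OC)cc1)C1=CCOC1=O`. The change is 4-methoxyphenyl in place of 2-carboxyphenyl on an amine nitrogen. Both compounds keep the same core, the acetate groups and the formate ester unchanged, and the amine nitrogen remains attached to the saturated chain carbon.

Within the data shown here, no measured pair shows what such a change does in this assay, so there is no step on which to rest an expectation. The estimate for compound 3 is therefore held near compound 2, with a step of a 1.4-fold lower number from compound 2 to compound 3 (0.15 log units; within the scatter) that is expected to stay within the scatter of repeated measurements. Compound 3 is expected to give about 22000 nM in this assay, with a range from 7000 nM to 70000 nM.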

Compound 3, half-maximal inhibitory concentration: 24200 nM
Estimate against measurement, compound 3: 1.1-fold (0.04 log units) below, and the stated range covers the measured number.
By their numbers in this assay, from the lowest: compound 1; then compounds 3 and 2 (each within the scatter of the next).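

In this assay, the first step read at this position is a 1.3-fold lower number from compound 2 to compound 3 (0.10 log units; within the scatter), so compound 2 and compound 3 cannot be told apart on this measurement. On the amine nitrogen, then, two differently substituted aryl groups give numbers within the scatter of each other, even though the carboxylic acid and the hydrogen-bond donor counted on 2-carboxyphenyl are absent from 4-methoxyphenyl and a methoxy group stands in their place. Nothing measured on these compounds speaks to why the two values lie so close.

Because the group and its place on the ring change together in this single step, the compounds shown do not separate the two changes; 4-carboxyphenyl and 2-methoxyphenyl would pull them apart. Also open, on these data alone, is whether any aryl group on the nitrogen matters to the number at all, a question that plain phenyl, benzyl or a short alkyl chain such as ethyl on the same amine nitrogen would address in this assay.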